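Removing the chloro from compound 3

The source may report more compounds than this note shows. Statements on the series, on what has been measured and on what is new or still open speak of the compounds shown alone.

Values in a functional assay on HCT-116 cells (Homo sapiens) for antiproliferative activity, read by MTT assay, with a stated time of 72 h; on this read-out higher numbers stand for weaker inhibition and lower numbers for stronger inhibition:
- Compound 1 `O=C1COc2ccc(-c3cnc4ccccc4c3)cc2N1C1CCCCC1`: > 40000 nM, a limit
- Compound 2 `O=C1COc2ccc(-c3cnc4ccccc4c3)cc2N1c1ccc(F)cc1`: > 40000 nM, a limit
- Compound 3 `O=C1COc2ccc(-c3cnc4ccccc4c3)cc2N1c1ccc(Cl)cc1`: 36100 nM
- Compound 4 `O=C1COc2ccc(-c3cnc4ccccc4c3)cc2N1c1ccccc1`: not yet measured

Within the data shown here, compound 3 gives the only actual number, 36100 nM. The other two compounds sit at the limit of > 40000 nM in this assay, at which 2 of the 3 values shown sit.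

Compound 4 has hydrogen in place of chloro on an aromatic carbon.

Among the measured compounds shown here, two measured steps bear on this change: an at least 1.1-fold lower number from compound 2 to compound 3 (0.04 log units; that floor lies within the scatter), and an at least 1.1-fold lower number from compound 1 to compound 3 (0.04 log units; that floor lies within the scatter). Both give only a floor, so neither shows a real gain from the chloro. The expected move, a 1.1-fold higher number from compound 3 to compound 4 (0.04 log units; within the scatter), is small, towards weaker inhibition if anything, and no step beyond the scatter is expected.

For compound 4 the estimated value is 40000 nM, with an expected range of 22000 nM to 70000 nM.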

Compound 4, half-maximal inhibitory concentration: > 40000 nM
Compound 4 gave a limit, no number (the forecaster's own chance of this, stated with the estimate: 65%); the middle value lies on the limit itself.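

In this assay, the change from 4-chlorophenyl to phenyl gives an at least 1.1-fold higher number from compound 3 to compound 4 (0.04 log units; that floor lies within the scatter), so even against the unsubstituted phenyl, the chloro shows no gain beyond the scatter. The value of compound 4 is a limit, not a number. The steps among compounds 1, 2 and 4 cannot be read, and the series mostly rests on one ceiling: the limit of > 40000 nM in this assay, at which 3 of the 4 values shown sit.

On these data alone, whether a methoxy, an amine or a carboxylic acid in place of the chloro moves the number beyond the scatter remains open.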